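The compounds below may be only part of what the source reports. "The series", "measured", "known", "first", "only" and "open" are said of these compounds alone.

Measured so far:
compound 1 `Nc1ccc(C(=O)NCCCOc2cccc(CN3CCCCC3)c2)cc1`, in a functional assay on cardiac atrium for antagonist activity at histamine H2 receptor (Cavia porcellus) (a higher number here means a more potent compound, by a factor of ten per unit of this negative logarithm, a lower number a less potent compound), compound 1 gives 6.82;
compound 2 `N#CN/C(=N\CCNC(=O)c1ccncc1)NCCCOc1cccc(CN2CCCCC2)c1`, in this assay compound 2 gives 6.89;
compound 3 `N#CN/C(=N\CCCCCCNC(=O)c1ccccc1)NCCCOc1cccc(CN2CCCCC2)c1`, in this assay compound 3 gives 6.6.

Compound 2 stands at the top of the three numbers, but its gap to compound 1 and its gap to compound 3 both lie within the scatter, so the three are not separable on this evidence. Compound 4 `N#CN/C(=N\CCNC(=O)CCCc1ccccc1)NCCCOc1cccc(CN2CCCCC2)c1` is not yet measured. It differs from compound 2 by 3-phenylpropyl in place of pyridin-4-yl on a carbonyl carbon, the rest of the molecule unchanged. For the measured compounds named here, no measured pair isolates this change, so its size cannot be read from the data. Compound 3 at 6.6 and compound 1 at 6.82 show that variation at this end of the molecule has so far stayed within the scatter. For compound 4 the expected step is a number 0.19 log units lower from compound 2 to compound 4 (within the scatter), not beyond the scatter. Compound 4 is estimated at 6.7, with a range from 6.2 to 7.2.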

Compound 4, negative logarithm of the antagonist equilibrium constant: 6.45
For compound 4 the middle estimate is 0.25 log units above the measured one; measured number inside the range.
By their numbers in this assay, from the lowest: compounds 4, 3, 1 and 2 (each within the scatter of the next, the first and the last beyond it).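

On the carbonyl carbon, 3-phenylpropyl in place of pyridin-4-yl gives a number 0.44 log units lower from compound 2 to compound 4 (beyond the scatter) in this assay. For the compounds shown here, this is the first isolated change, and it shows that the group at this position can move the number beyond the scatter. No available evidence accounts for the step.

On these data alone, the change removes the ring nitrogen and adds a carbon chain together, so their separate contributions remain open. A 3-(pyridin-4-yl)propyl group or a phenyl group on the same carbonyl carbon would separate them.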